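Butyl in place of butoxy at the assay limit

The compounds below may be only part of what the source reports. "The series", "measured", "known", "first", "only" and "open" are said of these compounds alone.

In an ADME assay on cells (Fibroblast, Homo sapiens) for inhibition, read by MTT assay, with a stated time of 24 h (on this read-out lower numbers stand for stronger inhibition and higher numbers for weaker inhibition), compound 1 (`Nc1ccc(C(=O)N/N=C/c2ccc3c(c2)no[n+]3[O-])cc1`) gives > 200000 nM as a limit of the assay. Compound 2 (`CCCOc1ccc(C(=O)N/N=C/c2ccc3c(c2)no[n+]3[O-])cc1`) gives > 200000 nM as a limit of the assay. Compound 3 (`CCCCOc1ccc(C(=O)N/N=C/c2ccc3c(c2)no[n+]3[O-])cc1`) gives > 200000 nM as a limit too, so it has no number of its own. For the measured compounds named here, it stands with the other two compounds, as the summary of the series shows: the limit of > 200000 nM in this assay, at which 3 of the 3 values shown sit, and no measured value so far.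

Compound 4 (`CCCCc1ccc(C(=O)N/N=C/c2ccc3c(c2)no[n+]3[O-])cc1`) carries butyl in place of butoxy on an aromatic carbon, para to a large group (butyl in place of butoxy on an aromatic carbon).

Going by the values given here, three measured steps bear on this change, and none gives a size: a step that the two limits leave unreadable from compound 1 to compound 2 and a step that the two limits leave unreadable from compound 1 to compound 3 and a step that the two limits leave unreadable from compound 2 to compound 3 in this assay. The swaps at this same carbon and the chain extension therefore fix no direction for the new step. The working expectation is that compound 4 stays with compound 3 at the limit, with no step beyond the scatter and no direction favoured. Estimated in these terms is a step that the limit leaves unreadable from compound 3 to compound 4 in this assay. For compound 4 the expected value is 250000 nM with an estimated range from 100000 nM to 500000 nM in this assay, most likely reported only as a limit.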

Compound 4, half-maximal inhibitory concentration: > 200000 nM
Compound 4: only a limit was reported; the forecaster's own chance of this, stated with the estimate: 80%; the middle value lies beyond the limit too.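

For the compounds shown here, no step to compound 4 from compound 1, compound 2 or compound 3 can be read in this assay, and all four compounds stand only as limits of the assay: the limit of > 200000 nM in this assay, at which 4 of the 4 values shown sit.

In this assay the compounds shown leave open how far beyond the limit each lies, and whether any group at this aromatic carbon gives a measurable value.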